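The source may report more compounds than this note shows. Statements on the series, on what has been measured and on what is new or still open speak of the compounds shown alone.

Measured compounds:
Compound 1 `CCCCCCCCc1ccc(OCC(=O)Cn2nnc(-c3ccc(Cl)cc3)n2)cc1`: 35 nM
Compound 2 `CCCCCCCCc1ccc(OCC(=O)Cn2nnc(-c3cccnc3)n2)cc1`: 23 nM
Compound 3 `CCCCCCCCc1ccc(OCC(=O)Cn2nnc(-c3ccccn3)n2)cc1`: 18 nM

Among the measured compounds shown here, in an assay on microsomes from brain for inhibition of Fatty-acid amide hydrolase 1 (Rattus norvegicus), read by fluorescence and HPLC, with a stated time of 60 min (on this read-out lower numbers stand for stronger inhibition and higher numbers for weaker inhibition), compound 1 carries the highest of the three numbers, but no measured step separates the set beyond the scatter: a 1.5-fold lower number from compound 1 to compound 2 (0.18 log units; within the scatter), a 1.9-fold lower number from compound 1 to compound 3 (0.29 log units; within the scatter), and a 1.3-fold lower number from compound 2 to compound 3 (0.11 log units; within the scatter). The three compounds therefore count as indistinguishable on this read-out, and compound 1 is a reference point rather than a weak member.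

Compound 4 `CCCCCCCCc1ccc(OCC(=O)Cn2nnc(-c3ccc(C(=O)O)cc3)n2)cc1` is not yet measured. Relative to compound 1 the change is carboxy in place of chloro on an aromatic carbon. The measured steps each exchange the whole aryl group on the tetrazole for a pyridyl ring and each stays within the scatter, so exchange at this part of the shared core has so far moved the number little. For the measured compounds named here, none of those steps introduces a carboxy, a hydrogen-bond donor or an acceptor at this place, so they bear on compound 4 only as a sign that the position is tolerant; the carboxy itself has no precedent here.

On that basis compound 4 is expected to stay near compound 1, with a step of a 1.7-fold higher number from compound 1 to compound 4 (0.23 log units; within the scatter) in this assay, most likely within the scatter or a small weakening. The estimate for compound 4 in this assay is 60 nM, with a range from 15 nM to 250 nM.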

Compound 4, half-maximal inhibitory concentration: 90 nM
For compound 4 the middle estimate is 1.5-fold (0.18 log units) below the measured one; the range from low to high includes it.
By their numbers in this assay, from the lowest: compounds 3, 2 and 1 (each within the scatter of the next); then compound 4.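

In this assay the position proves less tolerant than the pyridyl exchanges suggested: carboxy in place of chloro, on an aromatic carbon para to a large group, gives (a 2.6-fold higher number from compound 1 to compound 4 (0.41 log units; beyond the scatter)), whereas the steps among compounds 1, 2 and 3 all stay within the scatter. The same separation appears against both pyridyl compounds (a 3.9-fold higher number from compound 2 to compound 4 (0.59 log units; beyond the scatter); a 5.0-fold higher number from compound 3 to compound 4 (0.70 log units; beyond the scatter)), so compound 4 stands apart from all three, although each step remains modest and the change is tolerated to that extent. Nothing available here accounts for the shift.

On these data alone, it remains open whether the step belongs to the carboxylic acid itself or would also appear with a methyl ester or a primary amide at the same place, which would separate the effect of the free acid from that of a carbonyl group in general. Also open, as far as these compounds go, is whether a carboxy on the pyridin-2-yl or pyridin-3-yl ring would bring a step of similar size, or whether this result holds only for the 4-carboxyphenyl group.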